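Swapping a Chlorobenzyl for a Bromophenyl on Sulfur

The source may report more compounds than this note shows. Statements on the series, on what has been measured and on what is new or still open speak of the compounds shown alone.

Measured so far:
- compound 1, `COc1ccccc1/C=C(\C(=O)c1ccc(Cl)cc1)S(=O)(=O)Cc1ccc(Cl)cc1`: 25000 nM
- compound 2, `COc1ccccc1/C=C(\C(=O)c1ccc(Cl)cc1)S(=O)(=O)c1ccc(Br)cc1`: 10000 nM
- compound 3, `COc1ccc(/C=C(/SCc2ccc(Cl)cc2)C(=O)c2ccc(Cl)cc2)cc1`: 10000 nM

All three were tested in a functional assay on DU-145 cells (Homo sapiens) for inhibition, read by trypan blue exclusion, with a stated time of 96 h; on this read-out lower numbers stand for stronger inhibition of growth and higher numbers for weaker inhibition of growth. Compound 1 and compound 2 share a core and differ in one place: 4-bromophenyl in place of 4-chlorobenzyl on a sulfonyl sulfur. That change gives a 2.5-fold lower number from compound 1 to compound 2 (0.40 log units; beyond the scatter). Compound 3 stands level with compound 2 at the digits shown, and it sits well apart from compound 1. How the core of compound 3 differs from the core of compound 1 is not broken down here.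

Compound 4, `COc1ccc(/C=C(/Sc2ccc(Br)cc2)C(=O)c2ccc(Cl)cc2)cc1`, has not yet been tested. It differs from compound 3 in one place: 4-bromophenyl in place of 4-chlorobenzyl on a sulfur. Within the data shown here, this is the same kind of change as the one from compound 1 to compound 2, but not the same: there the place was a sulfonyl sulfur, here it is a sulfur whose other neighbour is a double-bonded chain carbon.

Among the measured compounds shown here, the only guide is the single earlier step, so the expectation is a modest improvement of about the same size, with added uncertainty from the different place. This rests on an expected step of a 2.0-fold lower number from compound 3 to compound 4 (0.30 log units; within the scatter). Compound 4 is therefore estimated to come out near 5000 nM, most likely from 1500 nM up to 15000 nM.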

Compound 4, concentration for 50% growth inhibition: 50000 nM
Estimate against measurement, compound 4: 10-fold (1.00 log units) below, outside the stated range (above it).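

In this assay, putting 4-bromophenyl in place of 4-chlorobenzyl on the sulfur of the second core gives a 5.0-fold higher number from compound 3 to compound 4 (0.70 log units; beyond the scatter), so here the number goes up rather than down. Set beside the earlier step on the sulfonyl core, the same swap runs in the opposite direction, and the gap is larger than repeat measurements would explain: the same change on two cores in this assay, a 2.5-fold lower number (0.40 log units; beyond the scatter) from compound 1 to compound 2 and a 5.0-fold higher number (0.70 log units; beyond the scatter) from compound 3 to compound 4, 13-fold (1.10 log units) apart, beyond the scatter of two such steps. This shows that, for these two pairs, the effect of the swap does not carry from one core to the other, but it does not show which difference between the cores reverses the direction, and two pairs give no rule for any further core in the series.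

The swap also changes two things at once, chlorine to bromine and benzyl to phenyl, and the compounds shown leave open which of these drives each step; a 4-bromobenzyl or a 4-chlorophenyl group on the same sulfur would pull the two apart. Also open, from the compounds shown here alone, is how either core responds to a group of a different kind at this place, such as an amine or a carboxylic acid carried on a longer chain.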